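Bromo for methyl on the pendant phenyl, across two cores

The source may report more compounds than this note shows. Statements on the series, on what has been measured and on what is new or still open speak of the compounds shown alone.

Compound 1 `Cc1ccc(-c2cc3c(=N)sc(=S)[nH]c3n2-c2ccccc2)cc1` and compound 2 `N=c1sc(=S)[nH]c2c1cc(-c1ccc(Br)cc1)n2-c1ccccc1` share one core. In a functional assay on the whole organism for inhibition, with Rattus norvegicus as the target, read by ELISA, with stated times of 30 min and 6 h, at a dose of 30 mg/kg by the oral route (a higher number here means more inhibition at the dose given (going by the name of the read-out), a lower number less inhibition), compound 1 gives 0%. In this assay compound 2 gives 44%. The change between them is bromo in place of methyl on an aromatic carbon, and it made a step of a number 44 percentage points higher from compound 1 to compound 2 (beyond the scatter).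

Compound 3 `CCC(C)Sc1nc2c(cc(-c3ccc(C)cc3)n2-c2ccccc2)c(=N)s1` carries a second core; how that core differs from the core of compound 1 is not broken down here. In this assay compound 3 gives 2%. Compound 4 `CCC(C)Sc1nc2c(cc(-c3ccc(Br)cc3)n2-c2ccccc2)c(=N)s1` is unmeasured and differs from compound 3 by bromo in place of methyl on an aromatic carbon. The two place descriptions read alike, so this is the same change as from compound 1 to compound 2, now on the second core. Going by the values given here, the step is expected to resemble the earlier one, resting on a number 44 percentage points higher from compound 1 to compound 2 (beyond the scatter) seen on the first core, though with only one prior instance a smaller step cannot be excluded. In this assay the step from compound 3 to compound 4 is expected to be a number 33 percentage points higher from compound 3 to compound 4 (beyond the scatter). Compound 4 is estimated at 35% in this assay, between 10% and 60%.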

Compound 4, a percentage reported as inhibition, in the whole organism at one dose (the size of the read-out at that dose, not a potency): 70%
Beside the measured number, compound 4's estimate is 35 percentage points below it, and the stated range ends below it.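

In this assay, the change from 4-methylphenyl to 4-bromophenyl also raises the read-out on the core of compound 3, with a step of a number 68 percentage points higher from compound 3 to compound 4 (beyond the scatter). The direction carries from one core to the other, but the size of the step does not: the same change on two cores in this assay, a number 44 percentage points higher (beyond the scatter) from compound 1 to compound 2 and a number 68 percentage points higher (beyond the scatter) from compound 3 to compound 4, 24 percentage points apart, beyond the scatter of two such steps The two pairs show that the step depends on the core here, but they give no rule for any further core, do not say what sets the difference in size, and, with a read-out at one dose, say nothing about potency.

Open is how other groups on the same aromatic carbon would behave, such as chloro, methoxy or an amine, since only methyl and bromo are shown there on these two cores. Also open, going by these compounds, is whether the bromo step would persist on a core carrying a carboxylic acid or a longer chain.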